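The compounds below may be only part of what the source reports. "The series", "measured", "known", "first", "only" and "open" are said of these compounds alone.

Working notes on the series. All three measured compounds share the same core, varied at two arylic positions: compound 1 `O=C(/C=C\Nc1ccc(F)cc1)c1nc(-c2ccc(F)cc2)n2ccccc12`, compound 2 `O=C(/C=C\Nc1cnc2ccccc2c1)c1nc(-c2ccccc2)n2ccccc12` and compound 3 `COc1ccc(N/C=C\C(=O)c2nc(-c3ccccc3)n3ccccc23)cc1`. In a functional assay on MDA-MB-231 cells (Homo sapiens) for cytotoxicity, read by MTT assay, with a stated time of 48 h (a lower number here means a stronger inhibitor, a higher number a weaker inhibitor), compound 2 gives 12300 nM, the lowest of the three numbers. Compound 1 gives 25100 nM and compound 3 gives 28300 nM, so compound 2 stands beyond the scatter below both, though only modestly. Within the data shown here, the single one-place step among them, a 2.3-fold higher number from compound 2 to compound 3 (0.36 log units; beyond the scatter), concerns the amine-bound aryl and is not the change at hand.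

Compound 4 `O=C(/C=C\Nc1cnc2ccccc2c1)c1nc(-c2ccc(C(F)(F)F)cc2)n2ccccc12` is not yet measured in this assay. It differs from compound 2 by trifluoromethyl in place of hydrogen on an aromatic carbon. Among the measured compounds shown here, no measured step touches this phenyl ring on its own: compound 1 carries a fluorine on it but differs from compound 2 at the amine aryl as well, so its value shows only that both changes together moved the number up, beyond the scatter. The expectation for compound 4 therefore rests on compound 2 alone, with no directional evidence, and a step of a 1.0-fold lower number from compound 2 to compound 4 (0.01 log units; within the scatter) is expected, well inside the scatter. For compound 4 in this assay a value of 12000 nM is estimated, with a range from 5000 nM to 30000 nM.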

Compound 4, half-maximal inhibitory concentration: > 30000 nM
Compound 4: a limit, no number (the forecaster's own chance of this, stated with the estimate: 5%); at least 2.5-fold (0.39 log units) between middle value and limit.
By their numbers in this assay, from the lowest: compound 2; then compounds 1 and 3 (each within the scatter of the next). At a limit, above all of these: compound 4.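

With the quinolin-3-yl amine held fixed, trifluoromethyl in place of hydrogen on this phenyl ring, para to a large group, gives an at least 2.4-fold higher number from compound 2 to compound 4 (0.38 log units; beyond the scatter) in this assay. Among these compounds, this is the first step that isolates this position, and it shows that the position is not indifferent to substitution: the number moves up, beyond the scatter, with nothing else changed. The reading for compound 4 is a limit and not a number, so the step gives only a lower bound on the change: the limit of > 30000 nM in this assay, at which 1 of the 4 values shown sits.

As far as these compounds go, how far the true value lies past that limit remains open, as does whether the rise belongs to trifluoromethyl in particular or to any group at this place, a question that a chlorine, an amine or a carboxylic acid on the same carbon would help to settle. Also open, from the compounds shown here alone, is whether the same change has a similar effect when 4-methoxyphenyl replaces quinolin-3-yl on the amine nitrogen, which would show whether the two positions act independently.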